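The compounds below may be only part of what the source reports. "The series", "measured", "known", "first", "only" and "open" are said of these compounds alone.

Measured compounds:
- compound 1 `Cc1ccc(C)c(N2CCN(C(=O)c3oc(C)nc3-c3ccc(F)cc3)CC2)c1`: 358 nM
- compound 2 `Cc1nc(-c2ccc(F)cc2)c(C(=O)N2CCN(c3ccc(Cl)cc3)CC2)o1`: "not active" (no number reported), no number reported
- compound 3 `Cc1nc(-c2ccc(F)cc2)c(C(=O)N2CCN(c3cc(Cl)cc(Cl)c3)CC2)o1`: 52.1 nM

In a functional assay on HL-60 cells (Homo sapiens) for inhibition, read by MTT assay, with a stated time of 72 h (a lower number here means a stronger inhibitor, a higher number a weaker inhibitor), compound 1 stands highest of the two numbers; the nearest is compound 3, reached by a 6.9-fold lower number from compound 1 to compound 3 (0.84 log units; beyond the scatter). Compound 4 `Cc1ccc(C)c(N2CCN(C(=O)c3oc(C)nc3-c3ccccc3F)CC2)c1` is not yet measured. From compound 1 it differs only at the aryl group on the shared core: 2-fluorophenyl in place of 4-fluorophenyl on an aromatic carbon. Among the measured compounds shown here, none of the measured steps touches this position; the only measured step moves the group on the amine nitrogen in the ring, so it gives no guide here. With no comparable change in this assay, the expectation for compound 4 is a number close to compound 1, a 1.1-fold higher number from compound 1 to compound 4 (0.05 log units; within the scatter), not beyond the scatter. Compound 4 is thus estimated at 400 nM in this assay, within 130 nM to 1200 nM.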

Compound 4, half-maximal inhibitory concentration: 319 nM
The estimate for compound 4 lay 1.3-fold (0.10 log units) above the measured number; low and high end bracket the measured number.
By their numbers in this assay, from the lowest: compound 3; then compounds 4 and 1 (each within the scatter of the next).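

In this assay, among the compounds shown here, the step of a 1.1-fold lower number from compound 1 to compound 4 (0.05 log units; within the scatter) gives the first reading at the aryl group on the shared core, where the earlier steps changed only the group on the amine nitrogen. At this position, 2-fluorophenyl and 4-fluorophenyl cannot be told apart with the 2,5-dimethylphenyl group in place. No supporting data bear on this result.

Open, going by these compounds, is whether a methoxy group or a carboxylic acid on this aryl ring would shift the number. Also open, on these data alone, is whether 2-fluorophenyl would read the same alongside the 3,5-dichlorophenyl group of compound 3.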